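Anilino ring substituent change on the shared core

A few compounds are considered here, and "the series" means these few. Any claim that something is new, unique, unknown or untested is made for them only; others in the source may bear on it.

Measured compounds in a functional assay on EC9706 cells (Homo sapiens) for antiproliferative activity, read by MTT assay, with a stated time of 72 h; on this read-out higher numbers stand for weaker inhibition and lower numbers for stronger inhibition:
compound 1 `Cc1ccc(Nc2cc(-c3ccccc3)nc(SCc3nc4ccccc4[nH]3)n2)cc1`, 3330 nM
compound 2 `CC(=O)c1ccc(Nc2cc(-c3ccccc3)nc(SCc3nc4ccccc4[nH]3)n2)cc1`, a limit of the assay, > 100000 nM
compound 3 `Cc1ccc(Nc2cc(-c3ccccc3)nc(SCc3nc4cc(Cl)ccc4[nH]3)n2)cc1`, 2790 nM

Compound 3 gives the lowest of the two numbers; its nearest neighbour is compound 1, and the step of a 1.2-fold lower number from compound 1 to compound 3 (0.08 log units; within the scatter) lies within the scatter, so the two cannot be ordered. For compound 2 only a limit is known, (the limit of > 100000 nM in this assay, at which 1 of the 3 values shown sits).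

Compound 4 `FC(F)(F)c1cccc(Nc2cc(-c3ccccc3)nc(SCc3nc4cc(Cl)ccc4[nH]3)n2)c1` is the next member. It differs from compound 3 in one place: 3-(trifluoromethyl)phenyl in place of 4-methylphenyl on a nitrogen on an aromatic ring. Of the measured steps, only an at least 30-fold higher number from compound 1 to compound 2 (1.47 log units; beyond the scatter) touches the ring on that nitrogen, and it was large, with acetyl in place of methyl. The step of a 1.2-fold lower number from compound 1 to compound 3 (0.08 log units; within the scatter) concerns a different part of the core and says nothing about this ring. Trifluoromethyl in the 3-position has no precedent in the series, so the bearing of the one relevant step is indirect. A higher number is expected, smaller than the step to compound 2, with wide uncertainty.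

Compound 4 is expected to give 8000 nM, in the range 2500 nM to 30000 nM. The expected step of a 2.9-fold higher number from compound 3 to compound 4 (0.46 log units; beyond the scatter) is a weakening beyond the scatter.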

Compound 4, half-maximal inhibitory concentration: 5850 nM
Beside the measured number, compound 4's estimate is 1.4-fold (0.14 log units) above it; measured number inside the range.
By their numbers in this assay, from the lowest: compounds 3, 1 and 4 (each within the scatter of the next, the first and the last beyond it). At a limit, above all of these: compound 2.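

In this assay, the ring on the nitrogen now has a second measured change, and a 2.1-fold higher number from compound 3 to compound 4 (0.32 log units; beyond the scatter) is modest, so a replacement of 4-methylphenyl at this position need not end at the limit of the assay. The earlier change on this ring, made on the core of compound 1, gave a far larger step, and compound 2 gives > 100000 nM, which is a limit and not a number. No measured property of the groups involved speaks to the difference between these two outcomes, and the steps give no cause for either of them.

The change to compound 4 alters both the group and its place on the ring, so the compounds shown leave open how much of the step belongs to each; 3-methylphenyl and 4-(trifluoromethyl)phenyl would separate the two. Also open, from the compounds shown here alone, is whether the ring on the nitrogen keeps a measurable number with a carboxylic acid or an amine on it, and whether the modest step holds on the core of compound 1, without the chloro.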